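Hydroxyl to acid at the end of a butyl chain

The compounds below may be only part of what the source reports. "The series", "measured", "known", "first", "only" and "open" are said of these compounds alone.

Compound 2 `CCC(CC)(c1ccc(OCCCCO)c(C)c1)c1ccc(OCC(O)C(C)(C)C)c(OCC(O)C(C)(C)C)c1` stands at the top of the two numbers gathered so far: in an assay on cells for binding affinity to vitamin D3 receptor (Homo sapiens), read by fluorescence, tested at 1 uM (on this read-out higher numbers stand for more inhibition at the one concentration tested (going by the name of the read-out) and lower numbers for less inhibition), compound 2 gives 71%. Compound 1 `CCC(CC)(c1ccc(OS(=O)(=O)c2ccc(C)cc2)c(C)c1)c1ccc(OCC(O)C(C)(C)C)c(OCC(O)C(C)(C)C)c1` gives 43% in this assay. Within the data shown here, the one measured step, a number 28 percentage points higher from compound 1 to compound 2 (beyond the scatter), concerns 4-hydroxybutyl in place of (4-methylphenyl)sulfonyl on an oxygen on an aromatic ring.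

Compound 3 `CCC(CC)(c1ccc(OCCCC(=O)O)c(C)c1)c1ccc(OCC(O)C(C)(C)C)c(OCC(O)C(C)(C)C)c1` differs from compound 2 by carboxy in place of hydroxymethyl on a saturated chain carbon, three bonds along the chain from an oxygen on an aromatic ring. The measured step changed the whole group on the aromatic oxygen, whereas this change touches only the far end of the 4-hydroxybutyl chain, so that step gives no direct guide. Among the measured compounds shown here, with no step that covers this change, the expectation is a move of a number 6 percentage points lower from compound 2 to compound 3 (within the scatter), which is no step beyond the scatter in this assay. Compound 3 is estimated to give 65%, between 40% and 85%.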

Compound 3, a percentage reported as inhibition, at one concentration (the size of the read-out at that concentration, not a potency): 14%
For compound 3 the middle estimate is 51 percentage points above the measured one; measured number below the stated range.
By their numbers in this assay, from the lowest: compound 3; then compound 1; then compound 2.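

In this assay, the far end of the 4-hydroxybutyl chain proves sensitive: carboxy in place of hydroxymethyl gives a number 57 percentage points lower from compound 2 to compound 3 (beyond the scatter) and leaves the rest of the molecule unchanged. The earlier step replaced the whole group on the aromatic oxygen, whereas this one shows that a change confined to the chain end, three bonds along the chain from that oxygen, is enough to move the number beyond the scatter. Compound 3 also sits under the tosylate-bearing parent, as 3-carboxypropyl in place of (4-methylphenyl)sulfonyl gives a number 29 percentage points lower from compound 1 to compound 3 (beyond the scatter), and no measured evidence here accounts for the loss.

The compounds shown leave open whether a methyl ester or a primary amide at the chain end would behave like the hydroxyl or like the carboxylic acid. They also leave open whether a shorter or longer chain ending in a carboxylic acid would give the same low number.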